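This account rests on a few compounds, and the source may have more. Where it says the series, first, only, none or still open, it means among the compounds named here.

In an assay on isolated protein for inhibition of cathepsin S (Homo sapiens) (on this read-out higher numbers stand for weaker binding and lower numbers for tighter binding), compound 2 `N#C[C@@]1(NC(=O)[C@@H](CC(=O)N2CCOCC2)CC2CCCCC2)CCNC1` gives 123 nM, the highest of the two numbers recorded so far; the nearest is compound 1 `N#CC1(NC(=O)[C@@H](CC(=O)N2CCOCC2)CC2CCCCC2)CC1`, which in this assay gives 12 nM. For compound 3 `N#C[C@@]1(NC(=O)[C@@H](CC(=O)N2CCOCC2)CC2CCCCC2)CCN(C2CCCC2)C1` this assay returned "not determined" (no result reported). For the measured compounds named here, the single measured step, a 10-fold higher number from compound 1 to compound 2 (1.01 log units; beyond the scatter), placed 3-cyanopyrrolidin-3-yl where 1-cyanocyclopropyl had stood on an amide-type nitrogen. Compound 4 `CN1CCC(C#N)(NC(=O)[C@@H](CC(=O)N2CCOCC2)CC2CCCCC2)CC1` differs from compound 2 in this way: 4-cyano-1-methylpiperidin-4-yl in place of 3-cyanopyrrolidin-3-yl on an amide-type nitrogen. Going by the values given here, no measured step exchanges one such group for another of the same kind at that nitrogen, so the step from compound 1 to compound 2 bears on the present question only loosely, showing that a change of group there can cost a large amount. Nothing in the two numbers indicates whether the new group recovers that loss or adds to it. One therefore expects a step of a 1.2-fold higher number from compound 2 to compound 4 (0.09 log units; within the scatter) in this assay, close to the scatter and without a clear direction. Compound 4 is estimated at 150 nM, with a range from 40 nM to 550 nM.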

Compound 4, dissociation constant: 177 nM
Compound 4: the middle estimate sits 1.2-fold (0.07 log units) below what was measured, and the stated range covers the measured number.
By their numbers in this assay, from the lowest: compound 1; then compounds 2 and 4 (each within the scatter of the next).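

In this assay, 4-cyano-1-methylpiperidin-4-yl in place of 3-cyanopyrrolidin-3-yl on the amide-type nitrogen gives a 1.4-fold higher number from compound 2 to compound 4 (0.16 log units; within the scatter), so the six-membered ring with its methylated nitrogen and the five-membered ring with its free one cannot be told apart here. Set against 1-cyanocyclopropyl, the new group gives a 15-fold higher number from compound 1 to compound 4 (1.17 log units; beyond the scatter), which shows that the large gap to compound 1 is not confined to the 3-cyanopyrrolidin-3-yl group. Nothing measured alongside these numbers accounts for either step.

As far as these compounds go, whether that gap goes with the ring nitrogen or with ring size stays open; a carbon-only 1-cyanocyclohexyl group or a 4-cyanotetrahydropyran-4-yl group would separate the two. From the compounds shown here alone, with no number for compound 3, the effect of a cyclopentyl group on the ring nitrogen also remains unknown.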